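Compound 2 Gains a Methyl on Its Fused Ring

This account rests on a few compounds, and the source may have more. Where it says the series, first, only, none or still open, it means among the compounds named here.

Compound 1 `COc1ccc(-c2cn(/N=C/c3cc4ccccc4nc3Cl)c(N)n2)cc1` carries a methoxy group on its pendant aromatic ring, and in a functional assay on HCT-116 cells (Homo sapiens) for cytotoxicity, read by MTT assay, with a stated time of 48 h (a lower number here means a stronger inhibitor, a higher number a weaker inhibitor), compound 1 gives 31800 nM. Compound 2 `Nc1nc(-c2ccc(Cl)cc2)cn1/N=C/c1cc2ccccc2nc1Cl` has chloro in place of methoxy on an aromatic carbon. In this assay compound 2 reports only a limit, > 50000 nM, and not a number. That change gave an at least 1.5-fold higher number from compound 1 to compound 2 (0.19 log units; that floor lies within the scatter). Compound 3 `Nc1nc(-c2ccc(Br)cc2)cn1/N=C/c1cc2ccccc2nc1Cl` has bromo in place of methoxy on an aromatic carbon. In this assay compound 3 also reports only a limit, > 50000 nM. That change gave an at least 1.5-fold higher number from compound 1 to compound 3 (0.19 log units; that floor lies within the scatter), and between the two halogen compounds the step is a step that the two limits leave unreadable from compound 2 to compound 3. Compound 2 therefore stands at the limit of > 50000 nM in this assay, at which 2 of the 3 values shown sit, with no number of its own.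

Compound 4 `Cc1ccc2nc(Cl)c(/C=N/n3cc(-c4ccc(Cl)cc4)nc3N)cc2c1` differs from compound 2 by methyl in place of hydrogen on an aromatic carbon. For the measured compounds named here, none of the measured steps touches this fused ring; each of them alters the pendant ring, and two of them only reach the limit. Nothing measured here points in either direction, so compound 4 is expected to remain near the limit, with the step from compound 2 estimated as a step that the limit leaves unreadable from compound 2 to compound 4. Compound 4 is estimated at 60000 nM, with a range from 20000 nM to 150000 nM.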

Compound 4, half-maximal inhibitory concentration: > 50000 nM
Compound 4: only a limit was reported; the forecaster's own chance of this, stated with the estimate: 70%; the middle value lies beyond the limit too.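

In this assay compound 4 reports only a limit, > 50000 nM, and not a number. Compound 2 also reports only a limit, so the step between compound 2 and compound 4 cannot be read: the limit of > 50000 nM in this assay, at which 3 of the 4 values shown sit. The compounds shown leave open what methyl in place of hydrogen does on this ring in a compound with a readable number, such as compound 1.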